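Trimming the benzofuran amide down to a furan

The source may hold more compounds than are shown below. What is called first, only, known or untested is meant among the compounds shown, and "the series" means these compounds.

Two amides sharing one core have been measured in an assay on isolated protein for binding affinity to Sigma intracellular receptor 2 (Homo sapiens), read by radioligand binding; a higher number here means a weaker inhibitor, a lower number a stronger inhibitor. Compound 1 `COc1ccc(CN(C)CCCNC(=O)c2ccc3ccccc3c2)cc1OC` gives 126 nM in this assay. Compound 2 `COc1ccc(CN(C)CCCNC(=O)c2cc3ccccc3o2)cc1OC` gives 46 nM in this assay, the lower of the two numbers, with compound 1 sitting above it by a gap beyond the usual scatter. Compound 3 `COc1ccc(CN(C)CCCNC(=O)c2ccco2)cc1OC` has not yet been measured. It differs from compound 2 in one place: furan-2-yl in place of 1-benzofuran-2-yl on a carbonyl carbon. The fused benzene ring of the benzofuran is thus removed, leaving only the five-membered ring on the carbonyl carbon. For the measured compounds named here, no measured pair here reports what such a removal does, so the expectation rests on the general observation that the larger aromatic amide of compound 2 gives the stronger value 46 nM. A weakening step of a 3.9-fold higher number from compound 2 to compound 3 (0.59 log units; beyond the scatter) is expected in this assay. Compound 3 is therefore estimated at 180 nM, within a range from 60 nM to 600 nM.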

Compound 3, inhibition constant: > 5000 nM
Compound 3: only a limit was reported; the forecaster's own chance of this, stated with the estimate: 3%; middle value at least 27-fold (1.44 log units) away from the limit.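

In this assay, for the compounds shown here, the only change is furan-2-yl in place of 1-benzofuran-2-yl on a carbonyl carbon, and it gives an at least 100-fold higher number from compound 2 to compound 3 (2.03 log units; beyond the scatter). This shows that the group at this place on the amide carries much of the result: the shared core and the five-membered ring alone do not preserve the value of compound 2, so the fused six-membered ring matters here. The result for compound 3 is a limit, not a number: the limit of > 5000 nM in this assay, at which 1 of the 3 values shown sits.

The compounds shown leave open how much aromatic size this place needs, since a single removal cannot separate the effect of ring size from that of ring type. A phenyl group or a thiophen-2-yl group on the same carbonyl carbon would give further points of comparison.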